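Swapping Hydrogen for Chloro on the Aromatic Ring

The source may report more compounds than this note shows. Statements on the series, on what has been measured and on what is new or still open speak of the compounds shown alone.

For the measured compounds named here, compound 1 `O=c1[nH]nc2n(c1=O)CCN2c1ccccc1` is one of only two compounds so far measured in a functional assay on A549 cells (Homo sapiens) for antiproliferative activity, with a stated time of 72 h, tested at 50 ug/mL; on this read-out higher numbers stand for a stronger effect at the one concentration tested and lower numbers for a weaker effect. Under those conditions compound 1 gives 17%, which is the lower of the two numbers. The other measured compound, compound 2 `Cc1ccccc1N1CCn2c1n[nH]c(=O)c2=O`, differs from compound 1 in a single place, a methyl in place of hydrogen on an aromatic carbon, and in this assay compound 2 gives 29%. Going by the values given here, that one step, a number 12 percentage points higher from compound 1 to compound 2 (beyond the scatter), is the only measured guide available.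

Compound 3 `O=c1[nH]nc2n(c1=O)CCN2c1cccc(Cl)c1` has not yet been measured. Relative to compound 1 the change is chloro in place of hydrogen on an aromatic carbon. Among the compounds with values here, no measured step shows exactly this change; the methyl step is the nearest comparison, and it was modest. Like the methyl change, the change leading to compound 3 puts a single substituent where compound 1 carries a hydrogen on its aromatic ring, so a modest upward step is the most reasonable expectation, although a result within the scatter cannot be ruled out. On that basis compound 3 is expected to give 26%, within a range of 10% to 42%, corresponding to an expected step of a number 9 percentage points higher from compound 1 to compound 3 (within the scatter).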

Compound 3, a percentage reported as inhibition, at one concentration (the size of the read-out at that concentration, not a potency): 0%
Estimate against measurement, compound 3: 26 percentage points above; the whole stated range lies above it.
By their numbers in this assay, from the lowest: compound 3; then compound 1; then compound 2.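

In this assay, a single substituent on the aromatic ring does not always raise the number: chloro in place of hydrogen on an aromatic carbon, meta to a large group, gives a number 17 percentage points lower from compound 1 to compound 3 (beyond the scatter). Set beside a number 12 percentage points higher from compound 1 to compound 2 (beyond the scatter), which came with a methyl in place of hydrogen, this shows that changes on this ring can move the read-out in either direction, so the outcome of replacing a hydrogen here depends on the particular change and cannot be carried over from one substituent to another. Nothing available explains why the chloro change and the methyl change part ways in this way.

From the compounds shown here alone, compound 2 and compound 3 differ from each other in more than one place, so it remains open whether the fall seen with compound 3 belongs to the chloro group itself or to where it sits on the ring. Also open, going by these compounds, is how other groups at this same place would read, such as a methyl, a fluoro, a methoxy group, an amine or a carboxylic acid.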